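The source may hold more compounds than are shown below. What is called first, only, known or untested is meant among the compounds shown, and "the series" means these compounds.

Measured compounds:

- compound 1, `CC(C)=CCC/C(C)=C/CC/C(C)=C/C(=O)NC(=N)NC(=O)C=C(C)C`: 23400 nM
- compound 2, `CC(C)=CCC/C(C)=C/C(=O)NC(=N)N`: 52200 nM

Both were run in a functional assay on MCF7 cells (Homo sapiens) for inhibition, read by MTT assay, with a stated time of 72 h; a lower number here means a stronger inhibitor of growth, a higher number a weaker inhibitor of growth. Compound 1 gives the lowest number of the two; compound 2 sits above it, and the gap between the two values is beyond the usual scatter. Among the compounds with values here, no step between measured compounds is available, so the pair only shows that compound 1 inhibits growth more strongly than compound 2.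

Compound 3, `CC(C)=CCC/C(C)=C/CC/C(C)=C/C(=O)NC(=N)NC(=O)/C=C(\C)CCC=C(C)C`, has not yet been measured in this assay. It differs from compound 1 in one place: 3-methylbut-2-en-1-yl in place of hydrogen on a saturated chain carbon bound to a double-bonded chain carbon. There is no measured step of this kind in the series to lean on. The step from compound 1 to compound 3 is expected to be small, likely within the scatter or slightly toward a lower number, as a 1.6-fold lower number from compound 1 to compound 3 (0.19 log units; within the scatter). Compound 3 is therefore estimated at 15000 nM in this assay, with a range from 6000 nM to 40000 nM.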

Compound 3, concentration for 50% growth inhibition: 51200 nM
Estimate against measurement, compound 3: 3.4-fold (0.53 log units) below, and the stated range ends below it.
By their numbers in this assay, from the lowest: compound 1; then compounds 3 and 2 (each within the scatter of the next).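

In this assay, 3-methylbut-2-en-1-yl in place of hydrogen on a saturated chain carbon bound to a double-bonded chain carbon gives a 2.2-fold higher number from compound 1 to compound 3 (0.34 log units; beyond the scatter), the first step measured at this position. Growth inhibition at this place in the series therefore responds to chain extension: the 2,6-dimethylhepta-1,5-dien-1-yl end of compound 3 gives a weaker inhibitor than the 2-methylprop-1-en-1-yl end of compound 1, and one step cannot show whether further extension would continue that trend. No accompanying measurement bears on the reason for this step.

Still open, on these data alone, is whether the step depends on the double bond in the added group, which a saturated pentyl chain would test. Also open, as far as these compounds go, is how a chain ending in an amine or a carboxylic acid would compare with compound 1 at the same place.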